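Replacing a Methyl with a 4-Methylbenzyl on the Amine

A few compounds are considered here, and "the series" means these few. Any claim that something is new, unique, unknown or untested is made for them only; others in the source may bear on it.

Measured compounds and their numbers in an ADME assay on isolated protein for inhibition of Amine oxidase [flavin-containing] A (Homo sapiens), read by fluorescence and Amplex Red, with stated times of 15 min and 20 min; a lower number here means a stronger inhibitor, a higher number a weaker inhibitor:
compound 1, `C#CCN(CCCOc1ccc2ccc(=O)oc2c1)Cc1ccccc1`, gives 38600 nM;
compound 2, `C#CCN(C)CCCCOc1ccc2ccc(=O)oc2c1`, gives 3280 nM;
compound 3, `C#CCN(CCCOc1ccc2ccc(=O)oc2c1)Cc1ccc(C(C)C)cc1`, gives 77400 nM.

Compound 2 stands lowest of the three numbers in this assay; compound 1 sits well above it, and compound 3 further still, both gaps beyond the scatter. Within the data shown here, compound 2 carries a methyl on the amine nitrogen, whereas compound 1 and compound 3 carry a benzyl or a substituted benzyl there together with a shorter chain to the shared core, so no single measured step separates the methyl from the benzyl.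

Compound 4, `C#CCN(CCCCOc1ccc2ccc(=O)oc2c1)Cc1ccc(C)cc1`, is not yet measured. It differs from compound 2 in one place: 4-methylphenyl in place of hydrogen on a saturated chain carbon bound to an amine nitrogen.

Among the measured compounds shown here, the one measured step of a related kind is a 2.0-fold higher number from compound 1 to compound 3 (0.30 log units; within the scatter), which shows that a substituent on the benzyl ring moves the number little. For the measured compounds named here, the only guide to the methyl-to-benzyl change itself is the wide gap between compound 2 and the two benzyl-bearing compounds, which points upward. Compound 4 is therefore expected to give a higher number than compound 2, a step of about a 7.6-fold higher number from compound 2 to compound 4 (0.88 log units; beyond the scatter). The estimate for compound 4 in this assay is 25000 nM, within a range from 6000 nM to 90000 nM.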

Compound 4, half-maximal inhibitory concentration: 94500 nM
The estimate for compound 4 lay 3.8-fold (0.58 log units) below the measured number; measured number outside the range, above it.
By their numbers in this assay, from the lowest: compound 2; then compounds 1, 3 and 4 (each within the scatter of the next, the first and the last beyond it).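

In this assay, among these compounds, the step of a 29-fold higher number from compound 2 to compound 4 (1.46 log units; beyond the scatter) is the first direct reading of methyl to 4-methylbenzyl on the amine nitrogen with the chain to the shared core held the same. Among the earlier compounds, the methyl and the benzyl-type groups came with different chains, so the effect of this change could not be separated from the chain. The new step, large and beyond the scatter, shows that this single change weakens inhibition substantially at this position, although no measurement shown here accounts for the rise.

The compounds shown leave open how an ethyl, a cyclopropylmethyl or a 2-phenylethyl on the amine nitrogen would read with this same chain, and therefore whether the number climbs step by step or jumps once an aromatic ring enters. They also leave open whether a hydroxyl or a carboxylic acid on the benzyl ring, or a free hydrogen on the amine in place of the methyl, would bring the number back down.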